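A few compounds are considered here, and "the series" means these few. Any claim that something is new, unique, unknown or untested is made for them only; others in the source may bear on it.

compound 1 `Cc1ccc(CCCCOc2ccc3c(O)c([N+](=O)[O-])c(=O)oc3c2)cc1` gives 2500 nM
compound 2 `CCCc1c(OCCCOc2ccccc2)ccc2c(O)c([N+](=O)[O-])c(=O)oc12` gives 540 nM
compound 3 `CC(=O)c1ccc(OCCCOc2ccc3c(O)c([N+](=O)[O-])c(=O)oc3c2)cc1` gives 6100 nM

In a functional assay on ileum (Cavia porcellus) for antagonist activity (a lower number here means a stronger inhibitor, a higher number a weaker inhibitor), compound 3 gives 6100 nM and is the weakest inhibitor of the three measured compounds. The nearest number belongs to compound 1 at 2500 nM and the furthest to compound 2 at 540 nM, and both gaps lie beyond the scatter.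

The next compound to be measured is compound 4 `O=C(O)c1ccc(OCCCOc2ccc3c(O)c([N+](=O)[O-])c(=O)oc3c2)cc1`. It differs from compound 3 in one place, as counted here: hydroxy in place of methyl on a carbonyl carbon. This puts hydroxy in place of methyl on a carbonyl carbon, so that acetyl becomes carboxy.

Among the measured compounds shown here, the measured compounds offer no single-place step to serve as a direct guide, and they differ from each other in more than one place. Any expectation for this change in this assay is therefore a judgment with a wide margin. A moderate move toward a higher number, meaning a weaker inhibitor, is expected, and the estimated change is a 2.5-fold higher number from compound 3 to compound 4 (0.39 log units; beyond the scatter). A result with no change beyond the scatter would remain possible. Compound 4 is estimated at 15000 nM with an expected range from 3500 nM to 60000 nM in this assay.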

Compound 4, half-maximal inhibitory concentration: > 20000 nM
Compound 4 was reported as a limit; the forecaster's own chance of this, stated with the estimate: 15%; middle value at least 1.3-fold (0.12 log units) from the limit.
By their numbers in this assay, from the lowest: compound 2; then compound 1; then compound 3. At a limit, above all of these: compound 4.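

Compound 4 reads > 20000 nM in this assay, and this value is a limit of the assay, not a number. The step from acetyl to carboxy, with hydroxy in place of methyl on a carbonyl carbon, is the only single-place comparison among the compounds shown, and it gives an at least 3.2-fold higher number from compound 3 to compound 4 (0.51 log units; beyond the scatter), so this exchange of one heavy atom on the 4-acetylphenyl group weakens inhibition beyond the scatter, starting from a compound that was already the weakest of the earlier three. The step therefore sets only a lower bound, and its full size cannot be read: the limit of > 20000 nM in this assay, at which 1 of the 4 values shown sits.

The compounds shown leave open whether a methyl ester or a primary amide on the same carbonyl carbon would stay close to compound 3 or fall away as compound 4 does, so the loss cannot yet be tied to the hydroxy group itself. Compound 1 and compound 2 differ from compound 3 in more than one place, and they do not show how any single feature of the chain or the core contributes to their lower numbers.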